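The compounds below may be only part of what the source reports. "The series", "measured", "known", "first", "only" and "open" are said of these compounds alone.

Measured so far in a functional assay on SW-620 cells (Homo sapiens) for cytotoxicity, read by sulforhodamine B assay, with a stated time of 48 h; a higher number here means a weaker inhibitor, a lower number a stronger inhibitor:

- compound 1 `C[C@H]1CC[C@@H]2[C@@H](OC(=O)[C@]23CC(c2ccc(Cl)cc2)=NO3)[C@]2(C)C(=O)C=C[C@@]12O` gives 51000 nM
- compound 2 `C[C@H]1CC[C@@H]2[C@@H](OC(=O)[C@]23CC(c2ccccc2Br)=NO3)[C@]2(C)C(=O)C=C[C@@]12O` gives 44000 nM
- compound 3 `C[C@H]1CC[C@@H]2[C@@H](OC(=O)[C@]23CC(c2ccccc2Cl)=NO3)[C@]2(C)C(=O)C=C[C@@]12O` gives 9000 nM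

Compound 3 stands lowest of the three at 9000 nM. Compound 4 `Cc1cccc(C2=NO[C@]3(C2)C(=O)O[C@@H]2[C@H]3CC[C@H](C)[C@]3(O)C=CC(=O)[C@@]23C)c1` keeps the shared core but carries 3-methylphenyl in place of 2-chlorophenyl on a carbon with a double bond to nitrogen. Within the data shown here, two measured steps bear on this, a 5.7-fold lower number from compound 1 to compound 3 (0.75 log units; beyond the scatter) and a 4.9-fold lower number from compound 2 to compound 3 (0.69 log units; beyond the scatter), both modest and beyond the scatter. The third, a 1.2-fold lower number from compound 1 to compound 2 (0.06 log units; within the scatter), lies within it. Among the measured compounds shown here, no measured compound carries a methyl group, so the comparison is indirect. A modest move to a higher number in this assay is expected, and the estimated step is a 3.3-fold higher number from compound 3 to compound 4 (0.52 log units; beyond the scatter). Compound 4 is estimated at 30000 nM, with an expected range of 10000 nM to 90000 nM.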

Compound 4, half-maximal inhibitory concentration: 15000 nM
Estimate against measurement, compound 4: 2.0-fold (0.30 log units) above; low and high end bracket the measured number.
By their numbers in this assay, from the lowest: compounds 3 and 4 (each within the scatter of the next); then compounds 2 and 1 (each within the scatter of the next).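

In this assay, 3-methylphenyl on the carbon with a double bond to nitrogen lies within the scatter of 2-chlorophenyl (a 1.7-fold higher number from compound 3 to compound 4 (0.22 log units; within the scatter)), so among these compounds a halogen on the phenyl ring is not needed for the lower numbers. The same group stands apart from 2-bromophenyl (a 2.9-fold lower number from compound 2 to compound 4 (0.47 log units; beyond the scatter)) and from 4-chlorophenyl (a 3.4-fold lower number from compound 1 to compound 4 (0.53 log units; beyond the scatter)). Nothing available explains these differences. Still open, going by these compounds, is whether a methoxy group, an amine or a carboxylic acid in place of the methyl group would keep compound 4 at this level.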